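The source may hold more compounds than are shown below. What is called first, only, known or untested is meant among the compounds shown, and "the series" means these compounds.

Measured so far:
Compound 1 `O=C(O)c1cc2ccc(Cn3ccnc3)cc2s1` gives 18 nM in an assay for inhibition of Thromboxane-A synthase (Homo sapiens); a higher number here means a weaker inhibitor, a lower number a stronger inhibitor.
Compound 2 `O=C(O)c1csc2ccc(Cn3ccnc3)cc12` gives 1700 nM in this assay.

Compound 1 has the lowest of these two numbers; compound 2 has the higher number, and that gap lies beyond the usual scatter. Compound 3 `Cc1c(C(=O)O)sc2cc(Cn3ccnc3)ccc12` has not yet been measured. It differs from compound 1 by methyl in place of hydrogen on an aromatic carbon. Going by the values given here, no step of this kind has been measured here, so its size is uncertain. Since the change is limited to one methyl group, the step of a 1.4-fold higher number from compound 1 to compound 3 (0.14 log units; within the scatter) is expected to be small, in either direction, or none beyond the scatter. Compound 3 is therefore estimated at 25 nM, in the range 6 nM to 100 nM.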

Compound 3, half-maximal inhibitory concentration: 5.2 nM
The estimate for compound 3 lay 4.8-fold (0.68 log units) above the measured number, and the stated range ends above it.
By their numbers in this assay, from the lowest: compound 3; then compound 1; then compound 2.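

In this assay, methyl in place of hydrogen on this aromatic carbon, next to the ring atom that bears a carboxy group, gives a 3.5-fold lower number from compound 1 to compound 3 (0.54 log units; beyond the scatter) and so a modest gain beyond the usual scatter. This position therefore accepts one added carbon without any loss of inhibition, and the number even falls. Nothing at hand shows why this step occurs.

As far as these compounds go, whether a longer chain such as ethyl would lower the number further remains open. So does the effect of a chlorine atom or an amine at this place.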